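Ortho-Bromo Analogue of a Phthalazinone Amide Cytotoxicity Series

The source may report more compounds than this note shows. Statements on the series, on what has been measured and on what is new or still open speak of the compounds shown alone.

Measured so far:
- Compound 1, `COc1cc2c(Oc3ccc(NC(=O)c4nn(-c5ccccc5F)c(=O)c5ccccc45)cc3F)ccnc2cc1OCCCN1CCCC1`: 230 nM
- Compound 2, `COc1ccc(-n2nc(C(=O)Nc3ccc(Oc4ccnc5cc(OCCCN6CCCC6)c(OC)cc45)c(F)c3)c3ccccc3c2=O)cc1`: 1650 nM
- Compound 3, `COc1cc2c(Oc3ccc(NC(=O)c4nn(-c5ccccc5)c(=O)c5ccccc45)cc3F)ccnc2cc1OCCCN1CCN(C)CC1`: 450 nM

In a functional assay on NCI-H460 cells (Homo sapiens) for cytotoxicity, read by MTT assay, with a stated time of 72 h (on this read-out higher numbers stand for weaker inhibition and lower numbers for stronger inhibition), compound 3 stands second highest of the three numbers; its gap to compound 1 lies within the scatter, while its gap to compound 2 lies beyond it. Compound 4, `COc1cc2c(Oc3ccc(NC(=O)c4nn(-c5ccccc5Br)c(=O)c5ccccc45)cc3F)ccnc2cc1OCCCN1CCN(C)CC1`, differs from compound 3 by bromo in place of hydrogen on an aromatic carbon, on an aromatic carbon of a six-membered aromatic ring of carbon only, ortho to a large group. Among the measured compounds shown here, the only step on this ring, a 7.2-fold higher number from compound 1 to compound 2 (0.86 log units; beyond the scatter), moved a group to a different place and is a weak guide. Compound 1 carries fluorine at the same spot and gives 230 nM, close to compound 3. A step no larger than the scatter, a 1.4-fold lower number from compound 3 to compound 4 (0.15 log units; within the scatter), is expected. Compound 4 is estimated at 320 nM, between 120 nM and 800 nM.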

Compound 4, half-maximal inhibitory concentration: 290 nM
Estimate against measurement, compound 4: 1.1-fold (0.04 log units) above; measured number inside the range.
By their numbers in this assay, from the lowest: compounds 1, 4 and 3 (each within the scatter of the next); then compound 2.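

In this assay, adding bromo to the phenyl ring, ortho to a large group, gives a 1.6-fold lower number from compound 3 to compound 4 (0.19 log units; within the scatter), so this change alone leaves the number within the usual scatter. Among the compounds shown here, no earlier pair differed only at this position, so this is its first direct reading. Nothing measured here explains the result.

As far as these compounds go, whether an amine, a carboxylic acid or a longer chain at the same position would also stay within the scatter remains open. From the compounds shown here alone, it is also open whether bromo would give a similar step with the pyrrolidine side chain of compound 1.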